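The source may report more compounds than this note shows. Statements on the series, on what has been measured and on what is new or still open speak of the compounds shown alone.

Measured compounds:
- compound 1 `COc1cc(-c2nnc(SCC(=O)c3ccc(Cl)cc3)n2N2C(=O)c3ccccc3C2=O)cc(OC)c1OC` gives 20700 nM in a functional assay on PC-3M cells (Homo sapiens) for cytotoxicity, read by MTT assay, with a stated time of 48 h; on this read-out lower numbers stand for stronger inhibition and higher numbers for weaker inhibition
- compound 2 `COc1ccc(C(=O)CSc2nnc(-c3cc(OC)c(OC)c(OC)c3)n2N2C(=O)c3ccccc3C2=O)cc1` gives 32800 nM in this assay
- compound 3 `COc1cc(-c2nnc(SCC(=O)c3ccccc3C)n2N2C(=O)c3ccccc3C2=O)cc(OC)c1OC` gives > 200000 nM in this assay

Compound 3 stands at a limit of this assay and not at a number, as the limit of > 200000 nM in this assay, at which 1 of the 3 values shown sits, records. Compound 4 `COc1cc(-c2nnc(SCC(=O)c3ccc(Br)cc3)n2N2C(=O)c3ccccc3C2=O)cc(OC)c1OC` differs from compound 3 by 4-bromophenyl in place of 2-methylphenyl on a carbonyl carbon. Among the measured compounds shown here, two measured steps bear on this change from the reverse side: an at least 9.6-fold higher number from compound 1 to compound 3 (0.98 log units; beyond the scatter) and an at least 6.0-fold higher number from compound 2 to compound 3 (0.78 log units; beyond the scatter), both beyond the scatter, both running from a 4-substituted phenyl ring to the 2-methylphenyl ring. Between the two 4-substituted rings the step of a 1.6-fold higher number from compound 1 to compound 2 (0.20 log units; within the scatter) lies within the scatter, so the 4-chlorophenyl and 4-methoxyphenyl compounds read alike, and the 4-bromophenyl of compound 4 is expected to fall near them. The step of an at least 9.0-fold lower number from compound 3 to compound 4 (0.95 log units; beyond the scatter) is therefore expected to be a clear drop in the number, well beyond the scatter. For compound 4 an estimated value of 22000 nM is expected, within a range of 8000 nM to 70000 nM.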

Compound 4, half-maximal inhibitory concentration: 22600 nM
Compound 4: middle estimate off by 1.0-fold (0.01 log units), on the low side, and the stated range covers the measured number.
By their numbers in this assay, from the lowest: compounds 1, 4 and 2 (each within the scatter of the next). At a limit, above all of these: compound 3.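

Putting 4-bromophenyl in place of 2-methylphenyl on the carbonyl carbon gives an at least 8.8-fold lower number from compound 3 to compound 4 (0.94 log units; beyond the scatter) in this assay, so this change is now read directly, and a third 4-substituted phenyl ring stands apart from the 2-methylphenyl compound. Bromo in place of chloro gives a 1.1-fold higher number from compound 1 to compound 4 (0.04 log units; within the scatter) and bromo in place of methoxy gives a 1.5-fold lower number from compound 2 to compound 4 (0.16 log units; within the scatter), so the chloro, bromo and methoxy compounds read alike. The step to compound 4 gives only a bound on the size of the change because compound 3 is recorded at a limit and not at a number: the limit of > 200000 nM in this assay, at which 1 of the 4 values shown sits.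

Still open, from the compounds shown here alone, is whether the methyl group itself or its place on the ring sets compound 3 apart, which a 4-methylphenyl or 2-bromophenyl ring would help to separate. Also open, going by these compounds, is how a phenyl ring carrying an amine or a carboxylic acid would read in this assay.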